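Cytotoxicity on Vero cells: chloro in place of trifluoromethyl

The compounds below may be only part of what the source reports. "The series", "measured", "known", "first", "only" and "open" are said of these compounds alone.

This piece follows a single change in one assay, an ADME assay on Vero 76 cells (Chlorocebus sabaeus) for cytotoxicity, read by MTT assay, with a stated time of 96 h; a higher number here means that more compound is tolerated, a lower number that less compound is tolerated. Of the compounds shown here, two have been measured. Compound 1, `Clc1ccc(NCc2cn(-c3ccccc3)nc2-c2ccc(Br)cc2)cc1`, was tested more than once, and in this assay compound 1 gives 43000 nM; > 100000 nM (2 entries). Among the measured compounds shown here, compound 2, `Cc1ccc(-c2nn(-c3ccccc3)cc2CNc2ccc(C(F)(F)F)cc2)cc1`, gives 45000 nM in this assay, and that is the only number it has; a further entry gave no single number. Compound 1 and compound 2 differ in more than one place, so their values are only set side by side, and both sit in the same broad region.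

Compound 3, `Cc1ccc(-c2nn(-c3ccccc3)cc2CNc2ccc(Cl)cc2)cc1`, has not been measured yet. It differs from compound 2 by chloro in place of trifluoromethyl on an aromatic carbon. For the measured compounds named here, no measured pair in this set shows what such a swap does in this assay, so the expectation rests on the two values at hand. The step from compound 2 to compound 3 is expected to stay within the usual scatter, at a 1.2-fold higher number from compound 2 to compound 3 (0.09 log units; within the scatter). Compound 3 is therefore estimated at 55000 nM, with a range from 25000 nM to 130000 nM.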

Compound 3, half-maximal cytotoxic concentration: > 100000 nM
Compound 3 ended at the assay's limit; the forecaster's own chance of this, stated with the estimate: 30%; middle value at least 1.8-fold (0.25 log units) away from the limit.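

In this assay, among the compounds shown here, the swap of 4-(trifluoromethyl)phenyl for 4-chlorophenyl, where one heavy atom replaces four, gives the first direct reading of this change: an at least 2.2-fold higher number from compound 2 to compound 3 (0.34 log units; beyond the scatter), and so, at this position on an otherwise unchanged compound, chloro goes with more compound being tolerated. From the compounds shown here alone, compound 3 gives > 100000 nM, which is a limit of the assay and not a number, so the real size of the step remains unknown and only its lower bound can be read. Compound 1 also carries chloro and differs from compound 3 in one other place, yet its repeated entries did not agree, which warns against treating chloro alone as a guarantee of reaching the limit: the several entries of compound 1 in this assay, 43000 nM; > 100000 nM (2 entries).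

The compounds shown leave open whether other groups at this position, such as a methoxy group, an amine or a carboxylic acid, or simply hydrogen, would behave like chloro or like trifluoromethyl. They also leave open whether the same swap would give a similar step on the core of compound 1.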